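The compounds below may be only part of what the source reports. "The series", "measured", "known", "first", "only" and "open" are said of these compounds alone.

Measured so far:
Compound 1 `COc1ccc(-c2cc3ccccc3nc2/C=C/C(=O)c2ccc(OC)cc2OC)cc1`: 3210 nM
Compound 2 `COc1ccc(-c2cc3ccccc3nc2/C=C/C(=O)c2ccc(Br)s2)cc1`: < 100 nM, a limit of the assay rather than a number

In a functional assay on MDA-MB-231 cells (Homo sapiens) for antiproliferative activity, read by XTT assay, with a stated time of 72 h (a lower number here means a stronger inhibitor, a higher number a weaker inhibitor), compound 1 gives the only plain number shown; compound 2 reached the limit. The step of an at least 32-fold lower number from compound 1 to compound 2 (1.50 log units; beyond the scatter) is therefore a floor on its true size, because the limit of < 100 nM in this assay, at which 1 of the 2 values shown sits, caps what can be read. Compound 3 `COc1ccc(-c2cc3ccccc3nc2/C=C/C(=O)c2sccc2N)cc1` changes the same position: 3-aminothiophen-2-yl in place of 2,4-dimethoxyphenyl on a carbonyl carbon. Since a thiophene replacing the dimethoxyphenyl gave a large gain in that one step, a gain is expected here too, though the amino substituent leaves its size uncertain. Compound 3 is estimated at 350 nM (range 60 nM to 1800 nM), a step of a 9.2-fold lower number from compound 1 to compound 3 (0.96 log units; beyond the scatter) expected.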

Compound 3, half-maximal inhibitory concentration: > 10000 nM
Compound 3 was reported as a limit; the forecaster's own chance of this, stated with the estimate: 25%; middle value at least 28-fold (1.45 log units) from the limit.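

In this assay, a thiophene at this carbonyl carbon does not by itself bring a gain: the change to 3-aminothiophen-2-yl gives an at least 3.1-fold higher number from compound 1 to compound 3 (0.49 log units; beyond the scatter), the opposite direction to the change to 5-bromothiophen-2-yl. The two thiophenes also lie far apart, with an at least 100-fold higher number from compound 2 to compound 3 (2.00 log units; beyond the scatter), so the outcome depends on more than the ring alone. Compound 3 stands at a limit of the assay, so its steps are floors on the true sizes: the limit of > 10000 nM in this assay, at which 1 of the 3 values shown sits.

Going by these compounds, it remains open whether the amino group or its place on the ring goes with the loss. A plain thiophen-2-yl carrying no added group, or a chlorine in place of the bromine, would be informative here.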